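The compounds below may be only part of what the source reports. "The series", "measured", "known", "first", "only" and "open" are said of these compounds alone.

For the measured compounds named here, compound 2 `CC(C)(C)N(NC(=O)c1ccccc1)C(=O)c1ccccc1C(F)(F)F` gives 631 nM in an assay on cells for agonist activity at ecdysone receptor (Bombyx mori), read by a luciferase reporter, with a stated time of 24 h (on this read-out lower numbers stand for an effect already at smaller amounts and higher numbers for an effect only at larger amounts of compound), which is the higher of the two numbers measured so far. Compound 1 `CC(C)(C)N(NC(=O)c1ccccc1)C(=O)c1ccccc1Cl` gives 75.9 nM in this assay. Going by the values given here, the one measured step, an 8.3-fold higher number from compound 1 to compound 2 (0.92 log units; beyond the scatter), shows that swapping the group on this aromatic carbon shifted the read-out well beyond the scatter. Compound 3 `CCc1ccccc1C(=O)N(NC(=O)c1ccccc1)C(C)(C)C` differs from compound 2 by ethyl in place of trifluoromethyl on an aromatic carbon. Among the compounds with values here, no measured step involves ethyl at this place, so the step from compound 1 to compound 2 is the only guide, and it shows only that this position is sensitive to the group placed there. Ethyl is neither chloro nor trifluoromethyl, so the direction remains open. A modest fall back toward compound 1 is the expected outcome, a 3.2-fold lower number from compound 2 to compound 3 (0.50 log units; beyond the scatter). Compound 3 is therefore estimated at 200 nM, with a range from 50 nM to 800 nM.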

Compound 3, half-maximal effective concentration: 589 nM
The estimate for compound 3 lay 2.9-fold (0.47 log units) below the measured number; measured number inside the range.
By their numbers in this assay, from the lowest: compound 1; then compounds 3 and 2 (each within the scatter of the next).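

In this assay, ethyl in place of trifluoromethyl gives a 1.1-fold lower number from compound 2 to compound 3 (0.03 log units; within the scatter), so this position does not separate these two groups, although one has 4 heavy atoms and the other 2. Ethyl in place of chloro gives a 7.8-fold higher number from compound 1 to compound 3 (0.89 log units; beyond the scatter), so the earlier gap was not special to trifluoromethyl: compound 1, with chloro, now stands apart from both compound 2 and compound 3, and its number is the lowest of the three. Nothing available here explains why chloro differs from the other two groups.

Going by these compounds, whether the lower number belongs to chloro alone remains open, since a bromine atom, a methoxy group or an amine on this aromatic carbon could match compound 1 or could match compound 2 and compound 3. On these data alone, how a longer chain than ethyl would read here is also open.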